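The compounds below may be only part of what the source reports. "The series", "measured", "known", "first", "only" and "open" are said of these compounds alone.

Three compounds built on one shared core have numbers in a functional assay on NB-4 cells (Homo sapiens) for cytotoxicity, read by CCK-8 assay, with a stated time of 24 h; on this read-out higher numbers stand for weaker inhibition and lower numbers for stronger inhibition. Compound 1 `C=CC(=O)N1C(=O)CC(c2ccc(C(F)(F)F)cc2)Sc2ccccc21` gives 38600 nM, and compound 2 `C=CC(=O)N1C(=O)CC(c2ccc(C)cc2)Sc2ccccc21` gives 37300 nM. That is a 1.0-fold lower number from compound 1 to compound 2 (0.01 log units; within the scatter). Compound 1 carries trifluoromethyl on an aromatic carbon, and compound 2 carries methyl there. Compound 3 `C=CC(=O)N1C(=O)CC(C)Sc2ccccc21` gives 227000 nM, the highest number of the three and so the weakest inhibition seen so far. Reaching it took a 6.1-fold higher number from compound 2 to compound 3 (0.78 log units; beyond the scatter), with methyl in place of 4-methylphenyl on a saturated ring carbon.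

Compound 4 `C=CC(=O)N1C(=O)CCSc2ccccc21` changes that same carbon again: hydrogen in place of methyl on a saturated ring carbon. Within the data shown here, the most relevant evidence is the modest step from compound 2, a 6.1-fold higher number from compound 2 to compound 3 (0.78 log units; beyond the scatter), the only measured change at this carbon. Among the measured compounds shown here, it swapped a much larger group, however, and no measured pair shows hydrogen replacing methyl. The step of a 1.0-fold lower number from compound 1 to compound 2 (0.01 log units; within the scatter) lies elsewhere on the molecule and says little here. A small rise in the number is therefore the best guess, probably not beyond the scatter. The expected change is a 1.2-fold higher number from compound 3 to compound 4 (0.09 log units; within the scatter). For compound 4 the estimated value is 280000 nM, with an expected range of 110000 nM to 700000 nM.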

Compound 4, half-maximal inhibitory concentration: 22400 nM
Estimate against measurement, compound 4: 13-fold (1.10 log units) above; the measured number lies below the stated range.
By their numbers in this assay, from the lowest: compounds 4, 2 and 1 (each within the scatter of the next); then compound 3.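

At the saturated ring carbon next to the ring sulfur, taking away a single methyl gives a 10-fold lower number from compound 3 to compound 4 (1.01 log units; beyond the scatter) and so undoes a change of about the same size as the earlier step to methyl from 4-methylphenyl. Hydrogen and 4-methylphenyl at this carbon stay close, with a 1.7-fold lower number from compound 2 to compound 4 (0.22 log units; within the scatter) in this assay, so the 4-methylphenyl group is not required to reach this level, and the high number belongs to the methyl compound rather than to the loss of the aromatic ring. No measured evidence accounts for why one methyl group separates compound 3 from both compound 2 and compound 4.

From the compounds shown here alone, with only hydrogen, methyl and two substituted phenyl groups at this carbon, it remains open whether methyl is an isolated case or whether a longer chain such as ethyl or propyl, an unsubstituted phenyl ring, an amine or a carboxylic acid would also give a high number. Going by these compounds, every compound here also keeps the vinylcarbonyl group on the ring nitrogen, so what happens when a saturated propanoyl group replaces it also remains open.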